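The source may hold more compounds than are shown below. What is called first, only, known or untested is meant among the compounds shown, and "the series" means these compounds.

Measured compounds:
- Compound 1, `CCCCC[C@H](C(C)C)C(c1ccc(O)c(OC)c1)c1ccc(O)c(OC)c1`: in a functional assay on HeLa cells (Homo sapiens) for cytotoxicity, read by WST assay, with a stated time of 48 h (on this read-out lower numbers stand for stronger inhibition and higher numbers for weaker inhibition), compound 1 gives 9200 nM.
- Compound 2, `COc1cc(C(c2ccc(O)c(OC)c2)[C@@H](C)[C@H](C)CF)ccc1O`: compound 2 gives 37000 nM.
- Compound 3, `COc1cc(C(c2ccc(O)c(OC)c2)[C@@H](CO)C(C)C)ccc1O`: for compound 3 the read-out is a limit, > 100000 nM.

Compound 1 holds the lowest of the two numbers given; the nearest is compound 2, a step of a 4.0-fold higher number from compound 1 to compound 2 (0.60 log units; beyond the scatter). The step of an at least 10-fold higher number from compound 1 to compound 3 (1.03 log units; beyond the scatter) runs to the limit of > 100000 nM in this assay, at which 1 of the 3 values shown sits, as does an at least 2.7-fold higher number from compound 2 to compound 3 (0.43 log units; beyond the scatter). Among the measured compounds shown here, all three measured steps replace the group on the saturated chain carbon bound to two aromatic carbons, and each replacement that shortens the chain or brings in a fluoromethyl or hydroxymethyl group raises the number; no step lowers it.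

Compound 4, `CCCCCCCC[C@H](C(C)C)C(c1ccc(O)c(OC)c1)c1ccc(O)c(OC)c1`, differs from compound 1 by propyl in place of hydrogen on a saturated chain carbon, seven bonds along the chain from two aromatic carbons. This is a longer chain at the same branch where the measured steps shortened it, so the direction suggested by compound 2 and compound 3 points to a number no higher than that of compound 1, and a step of a 1.5-fold lower number from compound 1 to compound 4 (0.19 log units; within the scatter) is expected, at most modest and possibly within the scatter. Compound 4 is estimated at 6000 nM, with a range from 2000 nM to 25000 nM.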

Compound 4, half-maximal inhibitory concentration: 3100 nM
Estimate against measurement, compound 4: 1.9-fold (0.29 log units) above; measured number inside the range.
By their numbers in this assay, from the lowest: compound 4; then compound 1; then compound 2. At a limit, above all of these: compound 3.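

In this assay, among the compounds shown here, propyl in place of hydrogen gives a 3.0-fold lower number from compound 1 to compound 4 (0.47 log units; beyond the scatter), the first step in this set that lowers the number rather than raises it. The earlier steps shown here all replaced the whole group on the saturated chain carbon bound to two aromatic carbons, so they could not separate the chain end from the branch; this step leaves the branch untouched and shows that a change seven bonds along the chain from two aromatic carbons is enough on its own to move the read-out beyond the scatter, and that the hexyl chain of compound 1 is not the limit of what the series accepts at this place. Nothing among the data shown accounts for why the added propyl lowers the number.

Going by these compounds, whether a longer chain than that of compound 4 would lower the number further, level off or reverse the trend remains open. Also open, on these data alone, is whether the chain end accepts anything other than plain carbon, such as a terminal amine, a carboxylic acid or a phenyl ring, without losing the gain seen here.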